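Moving the Fluorine Around on a Pair Without Cytotoxicity

The source may report more compounds than this note shows. Statements on the series, on what has been measured and on what is new or still open speak of the compounds shown alone.

Compound 1: `O=c1nc(-c2ccccc2)c2cc(-c3cccnc3)ccc2[nH]1`, > 50000 nM
Compound 2: `O=c1nc(-c2ccccc2)c2cc(-c3cccc(F)c3)ccc2[nH]1`, > 50000 nM

Of the compounds shown here, two have been measured in an ADME assay on THP-1 cells (Homo sapiens) for cytotoxicity, read by MTT assay, with a stated time of 72 h; a lower number here means that less compound is needed, a higher number that more compound is needed for the effect. In this assay compound 1 gives > 50000 nM, which is a limit of the assay and not a number. Compound 2 gives > 50000 nM in this assay, again only a limit. The step that the two limits leave unreadable from compound 1 to compound 2 therefore cannot be read, because of the limit of > 50000 nM in this assay, at which 2 of the 2 values shown sit. Compound 2 thus stands at the upper edge of what this assay reports, with no measured number of its own.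

Compound 3 is `O=c1nc(-c2ccccc2)c2cc(-c3ccc(F)cc3)ccc2[nH]1`. Its change from compound 2 is 4-fluorophenyl in place of 3-fluorophenyl on an aromatic carbon. For the measured compounds named here, no measured step shows this particular move of the fluorine, and the one step that was measured is itself unreadable, so the only guidance is that both measured values sit at the same limit. Compound 3 is therefore expected to stay at that limit as well, a step that the limit leaves unreadable from compound 2 to compound 3 that is expected to mean no change beyond the scatter. The estimate for compound 3 in this assay is 80000 nM, within a range from 40000 nM to 200000 nM.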

Compound 3, half-maximal effective concentration: > 50000 nM
Compound 3: only a limit was reported; the forecaster's own chance of this, stated with the estimate: 85%; the middle value is on the limit's open side.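

In this assay compound 3 gives > 50000 nM, which is again a limit and not a number. The steps among compound 1, compound 2 and compound 3 cannot be read, because all three stop at the same limit: the limit of > 50000 nM in this assay, at which 3 of the 3 values shown sit. Going by these compounds, whether these three compounds differ in cytotoxicity, and at what concentration each would reach the effect, stays open.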